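The source may report more compounds than this note shows. Statements on the series, on what has been measured and on what is new or still open speak of the compounds shown alone.

Working notes on the series. Compound 1 `CC(C)N(Cc1cccc(OCCCCCC(=O)O)c1)C(=O)c1ccc(-c2ccsc2)cc1` and compound 2 `CCOC(=O)CCCCCOc1cccc(CN(C(=O)c2ccc(-c3ccc4ccccc4c3)cc2)C(C)C)c1` have been run in an ADME assay on HEK293 cells (Homo sapiens) for cytotoxicity, read by CellTiter-Glo and resazurin assay, with a stated time of 72 h; on this read-out lower numbers stand for an effect already at smaller amounts and higher numbers for an effect only at larger amounts of compound. For compound 1 the read-out is a limit of the assay, > 26000 nM. For compound 2 the read-out is likewise a limit of the assay, > 26000 nM. Going by the values given here, compound 2 therefore stands where every value so far stands, at the limit of > 26000 nM in this assay, at which 2 of the 2 values shown sit; no number is available for it, and no step between compound 1 and compound 2 can be read from two limits. Compound 3 `CCOC(=O)CCCCCOc1cccc(CN(C(=O)c2ccc(-c3cc(OC)cc(OC)c3)cc2)C(C)C)c1` remains to be measured in this assay. It differs from compound 2 by 3,5-dimethoxyphenyl in place of naphthalen-2-yl on an aromatic carbon. Among the compounds with values here, no step between measured compounds exists against which to gauge this change. Since compound 2 sits at the limit, the step that the limit leaves unreadable from compound 2 to compound 3 is expected to be none beyond the scatter. For compound 3 the expected value in this assay is 30000 nM, within 12000 nM to 80000 nM, most probably again reported only as a limit.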

Compound 3, half-maximal effective concentration: > 26000 nM
Compound 3 ended at the assay's limit; the forecaster's own chance of this, stated with the estimate: 80%; the middle value is on the limit's open side.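

In this assay, going by these compounds alone, compound 2 and compound 3 both stand only as limits of the assay, and no step between them can be read. The compounds shown leave open at what concentration, if any, cytotoxicity appears, and whether 3,5-dimethoxyphenyl and naphthalen-2-yl differ at all on this read-out.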